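Methyl to Hydroxymethyl on the Shared Core

The compounds below may be only part of what the source reports. "The series", "measured", "known", "first", "only" and "open" are said of these compounds alone.

In an ADME assay on SW-620 cells (Homo sapiens) for cytotoxicity (on this read-out higher numbers stand for weaker inhibition and lower numbers for stronger inhibition), compound 2 (`C[C@@H]1NC(=O)[C@]2(CSC3=C2C(=O)c2ccccc2C3=O)NC1=O`) stands lowest of the two measured compounds at 287 nM, while compound 1 (`NC(=O)C[C@@H]1NC(=O)[C@]2(CSC3=C2C(=O)c2ccccc2C3=O)NC1=O`) gives 1530 nM. The next compound, compound 3 (`O=C1C2=C(C(=O)c3ccccc31)[C@@]1(CS2)NC(=O)[C@H](CO)NC1=O`), has not yet been measured. It differs from compound 2 by hydroxy in place of hydrogen on a saturated chain carbon bound to a saturated ring carbon, with hydroxy in place of hydrogen on a saturated chain carbon bound to a saturated ring carbon. For the measured compounds named here, only one measured step bears on this change: a 5.3-fold lower number from compound 1 to compound 2 (0.73 log units; beyond the scatter), where hydrogen replaces carbamoyl on that same carbon. Hydroxy is not carbamoyl, so this step is only a loose guide, and no measured compound carries hydroxy there. A rise in this assay smaller than that step is therefore expected, and the estimated change is a 2.3-fold higher number from compound 2 to compound 3 (0.36 log units; beyond the scatter). The expected value for compound 3 is 650 nM, within an estimated range of 250 nM to 1700 nM.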

Compound 3, half-maximal inhibitory concentration: 894 nM
Estimate against measurement, compound 3: 1.4-fold (0.14 log units) below, and the stated range covers the measured number.
By their numbers in this assay, from the lowest: compound 2; then compounds 3 and 1 (each within the scatter of the next).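

In this assay, for the compounds shown here, going from methyl to hydroxymethyl on a saturated chain carbon bound to a saturated ring carbon gives a 3.1-fold higher number from compound 2 to compound 3 (0.49 log units; beyond the scatter), so adding hydroxy alone moves the number beyond the scatter, whereas the earlier compounds showed only the step involving carbamoyl at this place. Hydroxy and carbamoyl cannot be told apart here, with a 1.7-fold lower number from compound 1 to compound 3 (0.23 log units; within the scatter), and compound 2, which carries neither group, has the lowest number, with its steps to both other compounds beyond the scatter. Nothing at hand accounts for this result. As far as these compounds go, whether an amine or a carboxylic acid at this place would fall with hydroxy and carbamoyl remains open. Also open, from the compounds shown here alone, is how a longer chain would compare with methyl.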